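This account rests on a few compounds, and the source may have more. Where it says the series, first, only, none or still open, it means among the compounds named here.

Values in an assay for inhibition of 3-hydroxy-3-methylglutaryl-coenzyme A reductase (Rattus norvegicus); a higher number here means a weaker inhibitor, a lower number a stronger inhibitor:
Compound 1, `O=C1C[C@H](O)C[C@@H](/C=C/c2c(Cl)cc(Cl)cc2-c2cc(Cl)cc(Cl)c2)O1`, compound 1 gives 37 nM.
Compound 2, `COc1ccc(-c2cc(Cl)cc(Cl)c2/C=C/[C@@H]2C[C@@H](O)CC(=O)O2)cc1`, compound 2 gives 470 nM.
Compound 3, `Cc1cc(F)ccc1-c1cc(Cl)cc(Cl)c1/C=C/[C@@H]1C[C@@H](O)CC(=O)O1`, compound 3 gives 36 nM.

Compound 3 shows the lowest number of the three in this assay, but its separation from compound 1 is small, a 1.0-fold lower number from compound 1 to compound 3 (0.01 log units; within the scatter), so the two cannot be ordered; only compound 2 stands clearly apart, a 13-fold lower number from compound 2 to compound 3 (1.12 log units; beyond the scatter).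

Compound 4, `O=C1C[C@H](O)C[C@@H](/C=C/c2c(Cl)cc(Cl)cc2-c2ccccc2)O1`, has not yet been measured in this assay. The change from compound 3 is phenyl in place of 4-fluoro-2-methylphenyl on an aromatic carbon. Among the compounds with values here, two measured steps bear on this position. Exchanging one outer aryl group for another left the number essentially unchanged, a 1.0-fold lower number from compound 1 to compound 3 (0.01 log units; within the scatter), whereas the exchange for a 4-methoxyphenyl produced a large rise, a 13-fold higher number from compound 1 to compound 2 (1.10 log units; beyond the scatter). Within the data shown here, a bare phenyl at this place has no measured counterpart, so the outcome is uncertain; the expectation is a step of a 1.7-fold higher number from compound 3 to compound 4 (0.22 log units; within the scatter), a modest rise that may well remain within the scatter. Compound 4 is therefore estimated at 60 nM, with a range from 20 nM to 200 nM.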

Compound 4, half-maximal inhibitory concentration: 80 nM
The estimate for compound 4 lay 1.3-fold (0.12 log units) below the measured number; the measured number falls inside the stated range.
By their numbers in this assay, from the lowest: compounds 3 and 1 (each within the scatter of the next); then compound 4; then compound 2.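

Phenyl gives this position an unsubstituted reference that the earlier compounds lacked: the bare ring carries a modest penalty against the 4-fluoro-2-methylphenyl group (a 2.2-fold higher number from compound 3 to compound 4 (0.35 log units; beyond the scatter)) and against the 3,5-dichlorophenyl group (a 2.2-fold higher number from compound 1 to compound 4 (0.33 log units; beyond the scatter)). Substitution on this outer ring does not act in one direction, however, as compound 2 goes against that gain: replacing its methoxy group with hydrogen improves the number (a 5.9-fold lower number from compound 2 to compound 4 (0.77 log units; beyond the scatter)). No measurement is available that accounts for these opposite outcomes.

Going by these compounds, it remains open how a single fluoro or a single methyl group on the phenyl ring would compare with the two together in compound 3. Also open, on these data alone, is what an amine or a carboxylic acid on this ring would do, and whether a saturated cyclohexyl ring could take the place of phenyl.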